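Notes on a fluoro swap at compound 3

The compounds below may be only part of what the source reports. "The series", "measured", "known", "first", "only" and "open" are said of these compounds alone.

In an ADME assay on microsomes from liver (Canis lupus familiaris) for metabolic stability, with a stated time of 10 min (a lower number here means that less of the compound is left, a higher number that more of the compound is left), compound 1 `FC(F)(F)c1ccccc1-c1ccc2[nH]c(C3=NC4(CCCCC4)CO3)nc2c1` gives 32% and compound 2 `FC(F)(F)c1ccccc1-c1ccc2[nH]c(C3=NCC4(CCCCC4)N3)nc2c1` gives 36%, two values within the scatter of each other. Compound 3 `FC(F)(F)c1ccccc1-c1ccc2[nH]c(C3=NOC4(CCCCC4)C3)nc2c1` gives 71%, the highest of the three and beyond the scatter from both of the others. No two of these compounds differ in one place only, so the series offers no measured step to work from.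

Compound 4 `Fc1ccccc1-c1ccc2[nH]c(C3=NOC4(CCCCC4)C3)nc2c1` keeps the rest of compound 3 and changes one group: fluoro in place of trifluoromethyl on an aromatic carbon, ortho to a large group (fluoro in place of trifluoromethyl on an aromatic carbon). Among the measured compounds shown here, all three measured compounds carry trifluoromethyl, so nothing measured so far tests this change, and the expectation is weakly founded. For the measured compounds named here, the only direct anchor is compound 3 at 71%, and the wide gap between that value and the other two leaves room for movement. In this assay, a small downward step is expected, within the scatter or close to it. The estimated change is a number 9 percentage points lower from compound 3 to compound 4 (within the scatter). Compound 4 is expected at 62%, with an estimated range of 42% to 80%.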

Compound 4, percent of the compound remaining: 47%
Compound 4: middle estimate off by 15 percentage points, on the high side; the measured number falls inside the stated range.
By their numbers in this assay, from the lowest: compounds 1 and 2 (each within the scatter of the next); then compound 4; then compound 3.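

In this assay, fluoro in place of trifluoromethyl on an aromatic carbon, ortho to a large group, gives a number 24 percentage points lower from compound 3 to compound 4 (beyond the scatter). Among the compounds shown here, this is the first single-place step, and it shows that this position is not indifferent to the group it carries: with the rest of the structure unchanged, this swap alone moves the read-out, and the high number of compound 3 is not kept once trifluoromethyl leaves. Nothing available bears on why the number falls with this exchange.

For the compounds shown here, with only two groups compared at this place, it remains open whether the read-out follows the group's heavy-atom count, the fluorine count or something else entirely; a chlorine atom, a methyl group or a methoxy group at the same place, or an unsubstituted ring, would help to separate these readings. Going by these compounds, it is also open whether the same swap would give a step of similar size on the core of compound 1 or the core of compound 2.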